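The source may report more compounds than this note shows. Statements on the series, on what has been measured and on what is new or still open speak of the compounds shown alone.

Working notes on the series. Compound 1 `Cn1c(CO[C@@H]2COc3nc([N+](=O)[O-])cn3C2)cnc1-c1ccc(F)cc1` and compound 2 `Cn1c(CO[C@@H]2COc3nc([N+](=O)[O-])cn3C2)cnc1-c1ccc(OC(F)(F)F)cc1` share one core, while compound 3 `O=[N+]([O-])c1cn2c(n1)OC[C@@H](OCc1cnn(-c3ccc(F)cc3)c1)C2` and the as yet unmeasured compound 4 `O=[N+]([O-])c1cn2c(n1)OC[C@@H](OCc1cnn(-c3ccc(OC(F)(F)F)cc3)c1)C2` share another; the difference between the two cores is not broken down here.

In an ADME assay on Vero cells (Chlorocebus sabaeus) for cytotoxicity, with a stated time of 72 h (a higher number here means a weaker inhibitor, a lower number a stronger inhibitor), compound 1 gives only a limit, > 128000 nM. Compound 2 likewise gives only a limit in this assay, > 128000 nM. Compound 3 also stops at a limit in this assay, > 128000 nM. The change from compound 1 to compound 2 is trifluoromethoxy in place of fluoro on an aromatic carbon, and the step that the two limits leave unreadable from compound 1 to compound 2 cannot be read because of the limit of > 128000 nM in this assay, at which 3 of the 3 values shown sit.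

Compound 4 carries the same change on the core of compound 3: trifluoromethoxy in place of fluoro on an aromatic carbon. The step from compound 3 to compound 4 is expected to be a step that the limit leaves unreadable from compound 3 to compound 4, resting on the limit of compound 3, > 128000 nM, and on (the limit of > 128000 nM in this assay, at which 3 of the 3 values shown sit). Compound 4 is therefore estimated at 200000 nM, with a range from 100000 nM to 500000 nM, and most likely only a limit will again be reported.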

Compound 4, half-maximal inhibitory concentration: > 128000 nM
Compound 4 gave a limit, no number; the forecaster's own chance of this, stated with the estimate: 85%; the middle value does not contradict the limit.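

No new step can be read: compound 3 and compound 4 both stop at a limit in this assay, so the size of the step between them stays unreadable because of this: the limit of > 128000 nM in this assay, at which 4 of the 4 values shown sit.

The compounds shown leave open whether trifluoromethoxy in place of fluoro, or the difference between the two cores, has any effect in this assay.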